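A few compounds are considered here, and "the series" means these few. Any claim that something is new, unique, unknown or untested is made for them only; others in the source may bear on it.

So far only two compounds have been tested in an ADME assay on MCF7 cells (Homo sapiens) for cytotoxicity, with a stated time of 72 h (a higher number here means a weaker inhibitor, a lower number a stronger inhibitor), and neither gives a real number. Compound 1 (`COc1ccccc1CNc1ncnc2c1ncn2C1CCCCO1`) reads > 100000 nM, which is a limit of the assay. Compound 2 (`COc1ccc(CNc2ncnc3c2ncn3C2CCCCO2)cc1`) reads > 100000 nM, which is also a limit. For the measured compounds named here, the one measured step, a step that the two limits leave unreadable from compound 1 to compound 2, therefore has no size that can be read, and the evidence comes down to the limit of > 100000 nM in this assay, at which 2 of the 2 values shown sit.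

Compound 3 (`COc1ccc(CNc2ncnc3c2ncn3C2CCCCO2)c(OC)c1`) is built from compound 2 by one change: methoxy in place of hydrogen on an aromatic carbon. In words, a methoxy takes the place of a hydrogen on an aromatic carbon, ortho to a large group and meta to a methoxy group. Going by the values given here, no measured step shows what adding such a group does in this assay, so the data offer no size and no direction for this change. With only the limit of compound 2, > 100000 nM, as a starting point, the reasonable expectation is no step beyond the scatter, and most likely another limit. The expected step is a number no higher from compound 2 to compound 3 (the limit leaves the size open). For compound 3 the estimated value is 100000 nM, with an expected range from 30000 nM to 300000 nM.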

Compound 3, half-maximal inhibitory concentration: > 25000 nM
Compound 3 ended at the assay's limit; the forecaster's own chance of this, stated with the estimate: 85%; the middle value is on the limit's open side.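

In this assay compound 3 gives > 25000 nM, which is a limit of the assay and not a number. Compound 1 and compound 2 also stand at limits, so neither step to compound 3 can be read. The compounds shown leave open what the added methoxy does and whether any of them has a readable value in this assay.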